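The compounds below may be only part of what the source reports. "The series", "measured", "known", "first", "only" and "open" are said of these compounds alone.

Three compounds share one core and differ only in the amine-bearing end of the chain that hangs from the urea nitrogen. Compound 1 `NCc1ncc([C@]23CC[C@@H](N(CCN4CCCC4)C(=O)Nc4ccc(F)c(C(F)(F)F)c4)C2C3)s1` carries a pyrrolidin-1-yl group and in a functional assay for antagonist activity at melanin-concentrating hormone receptor 1 (Homo sapiens) (on this read-out lower numbers stand for stronger inhibition and higher numbers for weaker inhibition), compound 1 gives 107 nM. Compound 2 `NCc1ncc([C@]23CC[C@@H](N(CCN4CC[C@H](O)C4)C(=O)Nc4ccc(F)c(C(F)(F)F)c4)C2C3)s1` has a hydroxy in place of hydrogen on a saturated ring carbon, and in this assay compound 2 gives 99 nM, a change of a 1.1-fold lower number from compound 1 to compound 2 (0.03 log units; within the scatter). Compound 3 `C[C@@H]1CN(CCCN(C(=O)Nc2ccc(F)c(C(F)(F)F)c2)[C@@H]2CC[C@]3(c4cnc(CN)s4)CC23)[C@@H](C)CN1` instead bears a (2,5-dimethylpiperazin-1-yl)methyl group; in this assay compound 3 gives 19 nM, the lowest of the three numbers, reached by steps of a 5.6-fold lower number from compound 1 to compound 3 (0.75 log units; beyond the scatter) and a 5.2-fold lower number from compound 2 to compound 3 (0.72 log units; beyond the scatter).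

Compound 4 `NCc1ncc([C@]23CC[C@@H](N(CCCN4CC5CC4CN5)C(=O)Nc4ccc(F)c(C(F)(F)F)c4)C2C3)s1` takes the next step in the same region: a group of 7 heavy atoms (5 carbon, 2 nitrogen; 2 five-membered non-aromatic rings with 1 hetero atom each) in place of a group of 8 heavy atoms (6 carbon, 2 nitrogen; one six-membered non-aromatic ring with 2 hetero atoms), on a saturated chain carbon, three bonds along the chain from an amide-type nitrogen. Among the measured compounds shown here, no measured pair shows this exact exchange. The two steps that bear on it, from compound 1 and compound 2 to compound 3, show that changes at this chain end move the number by a modest amount, while the change to compound 2 shows that a small alteration within the ring can leave it unchanged. Since the entering bicyclic group keeps the counted donor and acceptors, compound 4 is expected to stay near compound 3, with a step of a 2.1-fold higher number from compound 3 to compound 4 (0.32 log units; beyond the scatter) and more room upward than downward. In this assay compound 4 is therefore estimated at 40 nM, within a range from 14 nM to 130 nM.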

Compound 4, inhibition constant: 73 nM
Estimate against measurement, compound 4: 1.8-fold (0.26 log units) below; low and high end bracket the measured number.
By their numbers in this assay, from the lowest: compound 3; then compounds 4, 2 and 1 (each within the scatter of the next).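

In this assay, putting the group with 2 five-membered non-aromatic rings in place of 2,5-dimethylpiperazin-1-yl gives a 3.8-fold higher number from compound 3 to compound 4 (0.58 log units; beyond the scatter), even though both groups have the same counts of hydrogen-bond donors and acceptors and no net charge. At this place, three bonds along the chain from an amide-type nitrogen, those counts alone therefore do not set the number. A ring group with two nitrogens is also not enough to keep compound 4 apart from the groups with one nitrogen, with a 1.4-fold lower number from compound 2 to compound 4 (0.13 log units; within the scatter) and a 1.5-fold lower number from compound 1 to compound 4 (0.17 log units; within the scatter), and the low number of compound 3 remains the only one separated from the rest. No measurement shown gives a reason for the difference between these two groups.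

The compounds shown do not separate the effect of the two methyl groups from that of the piperazine ring, which unsubstituted piperazin-1-yl at the same chain end would address. They also do not separate chain length from the identity of the terminal group, since a pyrrolidin-1-yl on the chain of compound 3 would be needed to compare directly with compound 1.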